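Turning Compound 3 Into Its Mirror Image

The source may hold more compounds than are shown below. What is called first, only, known or untested is meant among the compounds shown, and "the series" means these compounds.

Three stereoisomers of one hydroxylated ring acid have been measured in an assay for inhibition of alpha-N-acetylgalactosaminidase (Gallus gallus), tested at 1000 uM; a higher number here means more inhibition at the concentration tested (going by the name of the read-out), a lower number less inhibition. Compound 1 `O=C(O)[C@H]1NC[C@H](O)[C@H](O)[C@H]1O` gives 21% in this assay. Compound 2 `O=C(O)[C@@H]1NC[C@@H](O)[C@@H](O)[C@@H]1O`, its mirror image, gives 7.2%, and compound 3 `O=C(O)[C@@H]1NC[C@@H](O)[C@H](O)[C@H]1O` gives 1.3%. Among the three, compound 3 sits at the low end: the step of a number 5.9 percentage points lower from compound 2 to compound 3 (within the scatter) lies within the scatter, while the step of a number 19.7 percentage points lower from compound 1 to compound 3 (beyond the scatter) lies beyond it. Among the compounds with values here, the only step in which all four stereocentres are inverted is a number 13.8 percentage points lower from compound 1 to compound 2 (beyond the scatter), because of the fact that compounds 1 and 2 differ only in the configuration as drawn.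

Compound 4 `O=C(O)[C@H]1NC[C@H](O)[C@@H](O)[C@@H]1O` has not yet been measured. Relative to compound 3, (the two compounds have the same atoms and bonds and differ only in configuration as drawn: 4 of 4 stereo elements differ (all stereocentres are inverted: mirror images); a stereocentre at a saturated ring carbon is drawn R in compound 3 and S in compound 4; a stereocentre at a saturated ring carbon is drawn R in compound 3 and S in compound 4; a stereocentre at a saturated ring carbon is drawn S in compound 3 and R in compound 4; a stereocentre at a saturated ring carbon is drawn S in compound 3 and R in compound 4). Within the data shown here, the one comparable change in the set, from compound 1 to compound 2, moved the inhibition by a modest amount, from the higher number to the lower. Compound 4 has no measured partner other than compound 3, and compound 3 already stands near the bottom of the range, so a drop of similar size cannot be expected; a rise of that order, or no change beyond the scatter, are both open. The estimated step of a number 8.7 percentage points higher from compound 3 to compound 4 (within the scatter) is therefore expected to be small and upward. In this assay compound 4 is estimated to give 10%, within a range of 0% to 30%.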

Compound 4, a percentage reported as inhibition, at one concentration (the size of the read-out at that concentration, not a potency): 0.2%
Compound 4: the middle estimate sits 9.8 percentage points above what was measured, and the stated range covers the measured number.
By their numbers in this assay, from the lowest: compounds 4, 3 and 2 (each within the scatter of the next); then compound 1.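

Inverting all four stereocentres has no single outcome in this assay: the change that set compound 1 apart from compound 2 yields a number 1.1 percentage points lower from compound 3 to compound 4 (within the scatter) in this other mirror-image pair, so the effect of inversion depends on the isomer it starts from. The further step, a number 7 percentage points lower from compound 2 to compound 4 (within the scatter) on a change of two stereocentres, completes the picture: compounds 2, 3 and 4 cannot be told apart here, and all of them sit close to the floor of the read-out. Compound 1 is now the only isomer that stands clear of the others, and a number 20.8 percentage points lower from compound 1 to compound 4 (beyond the scatter) on a change of two stereocentres can be put down to configuration alone because of one fact: the fact that compounds 1 and 4 differ only in the configuration as drawn.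

The compounds shown leave open which single stereocentre carries the gap, since every step here changes two or four of them at once, and a single concentration gives no potency for compound 1. They also leave open whether an amide or a hydroxymethyl group in place of the carboxylic acid would keep, raise or remove the inhibition seen with compound 1.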